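Branching the carbamate chain: propyl to isobutyl

The source may report more compounds than this note shows. Statements on the series, on what has been measured and on what is new or still open speak of the compounds shown alone.

Of the compounds shown here, three built on the shared core have been measured in a functional assay on PC-3 cells (Homo sapiens) for cytotoxicity, read by MTT assay, with a stated time of 72 h; a higher number here means a weaker inhibitor of growth, a lower number a stronger inhibitor of growth. Compound 1 `COc1ccc(OC(=O)Nc2ccc([Se]C#N)cc2)cc1` gives 44600 nM, compound 2 `CCCOC(=O)Nc1ccc([Se]C#N)cc1` gives 47400 nM, and compound 3 `O=C(Nc1ccc([Se][Se]c2ccc(NC(=O)OCc3ccccc3)cc2)cc1)OCc1ccccc1` gives 33500 nM. On these numbers compound 2 stands at the highest value of the three, yet its gap to compound 1 and its gap to compound 3 both fall within the scatter of repeat measurements, so the three cannot be separated. Compound 4 `CC(C)COC(=O)Nc1ccc([Se]C#N)cc1` is not yet measured. It differs from compound 2 by methyl in place of hydrogen on a saturated chain carbon bound to two saturated chain carbons. Among the measured compounds shown here, no pair of measured compounds carries this change, so the series gives no direction for it. The step from compound 2 to compound 4 is expected to stay within the scatter, a 1.1-fold lower number from compound 2 to compound 4 (0.02 log units; within the scatter). Compound 4 is estimated at 45000 nM, with a range from 25000 nM to 80000 nM.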

Compound 4, concentration for total growth inhibition: 47300 nM
The estimate for compound 4 lay 1.1-fold (0.02 log units) below the measured number; measured number inside the range.
By their numbers in this assay, from the lowest: compounds 3, 1, 4 and 2 (each within the scatter of the next).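

In this assay, among the compounds shown here, methyl in place of hydrogen on a saturated chain carbon bound to two saturated chain carbons gives a 1.0-fold lower number from compound 2 to compound 4 (0.00 log units; within the scatter) and provides the first readable step. At this position, propyl and isobutyl cannot be separated, so this single added methyl leaves no detectable difference in growth inhibition. No measurement at hand offers a reason for this result.

From the compounds shown here alone, whether a longer chain would separate from compound 2 remains open. So does whether an amine or a carboxylic acid at the chain end would do so.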